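The source may hold more compounds than are shown below. What is called first, only, known or untested is meant among the compounds shown, and "the series" means these compounds.

Measured in an ADME assay on QSG7701 cells (Homo sapiens) for cytotoxicity, read by MTT assay, with a stated time of 24 h; on this read-out higher numbers stand for weaker inhibition and lower numbers for stronger inhibition:
- compound 1 `COc1cc(O)cc(/C=C/c2ccc(OC)c(O)c2OC)c1` gives > 100000 nM (a limit)
- compound 2 `COc1cc(O)cc(/C=C/c2ccc(O)c(OC)c2OC)c1` gives > 100000 nM (a limit)

Compound 2 has no graded number on this read-out: its > 100000 nM is a limit of the assay and not a number. For the measured compounds named here, the record so far is the limit of > 100000 nM in this assay, at which 2 of the 2 values shown sit, and offers no graded step.

Compound 3 `COc1cc(O)cc(/C=C/c2cccc(OC)c2OC)c1` carries hydrogen in place of hydroxy on an aromatic carbon and the rest of the structure stays the same. Going by the values given here, no measured step is available to size this change, so in this assay the expected size of a step that the limit leaves unreadable from compound 2 to compound 3 is none beyond the scatter, with no direction expected. The estimate for compound 3 is 130000 nM with an expected range from 60000 nM to 300000 nM and a report as a limit is the likelier outcome.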

Compound 3, half-maximal inhibitory concentration: > 100000 nM
Compound 3 ended at the assay's limit (the forecaster's own chance of this, stated with the estimate: 85%); the middle value is on the limit's open side.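

In this assay no step can be read from compound 2 to compound 3, as both values are limits of the assay: the limit of > 100000 nM in this assay, at which 3 of the 3 values shown sit.

The compounds shown leave open whether any change to the shared core would give a graded value in this assay at all.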